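Moving the methyl from ring nitrogen to ring carbon

The compounds below may be only part of what the source reports. "The series", "measured", "known", "first", "only" and "open" are said of these compounds alone.

Compounds measured so far:
compound 1 `CCCC[C@H](NC(=O)OC(C(C)C)C(C)C)C(=O)C(=O)Nc1cc(-c2ccccc2)[nH]n1` — 12 nM
compound 2 `CCCC[C@H](NC(=O)OC(C(C)C)C(C)C)C(=O)C(=O)Nc1ccnn1C` — 1700 nM
compound 3 `CCCC[C@H](NC(=O)OC(C(C)C)C(C)C)C(=O)C(=O)Nc1ccnn1CCC(C)(C)C` — 1600 nM

In an assay on isolated protein for inhibition of cathepsin K (Rattus norvegicus) (on this read-out lower numbers stand for stronger inhibition and higher numbers for weaker inhibition), compound 2 stands at the highest of the three numbers; compound 3 is close to it, as a 1.1-fold lower number from compound 2 to compound 3 (0.03 log units; within the scatter) shows, whereas compound 1 lies far lower. Compound 4 `CCCC[C@H](NC(=O)OC(C(C)C)C(C)C)C(=O)C(=O)Nc1[nH]ncc1C` differs from compound 2 by 4-methyl-1H-pyrazol-5-yl in place of 1-methyl-1H-pyrazol-5-yl on an amide-type nitrogen. For the measured compounds named here, no measured step matches this move: the one recorded step, a 1.1-fold lower number from compound 2 to compound 3 (0.03 log units; within the scatter), changes only the group on the ring nitrogen and stays within the scatter. Going by the values given here, the values of compound 1 and compound 2, however, show that the only compound with a free ring nitrogen-hydrogen gives the far lower number. Compound 4 is therefore expected to fall well below compound 2, by about an 11-fold lower number from compound 2 to compound 4 (1.05 log units; beyond the scatter). For compound 4 the estimate is 150 nM, with a range of 30 nM to 800 nM.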

Compound 4, half-maximal inhibitory concentration: 5.5 nM
Beside the measured number, compound 4's estimate is 27-fold (1.44 log units) above it; the measured number lies below the stated range.
By their numbers in this assay, from the lowest: compound 4; then compound 1; then compounds 3 and 2 (each within the scatter of the next).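

In this assay, rearranging the same atoms gives a 310-fold lower number from compound 2 to compound 4 (2.49 log units; beyond the scatter), whereas the change on the ring nitrogen, a 1.1-fold lower number from compound 2 to compound 3 (0.03 log units; within the scatter), stayed within the scatter. On the amide-type nitrogen, 4-methyl-1H-pyrazol-5-yl in place of 1-methyl-1H-pyrazol-5-yl brings a hydrogen-bond donor and one hydrogen-bond acceptor fewer, with the heavy-atom count unchanged. Nothing measured here explains the size of this step. The free ring nitrogen-hydrogen and the methyl on ring carbon change together, so their shares stay unseparated. Going by these compounds, whether an ethyl group or a chlorine atom in place of that methyl would keep the low number also remains open.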